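Aryl amide variation in the shared core, compounds 1 to 3

The compounds below may be only part of what the source reports. "The series", "measured", "known", "first", "only" and "open" are said of these compounds alone.

Measured so far:
compound 1 `Cc1ccc(S(=O)(=O)NCc2ccc(CNC(=O)c3ccccc3Cl)cc2)cc1` — 10 nM
compound 2 `Cc1ccc(S(=O)(=O)NCc2ccc(CNC(=O)c3c(Cl)cc(Cl)cc3Cl)cc2)cc1` — 10 nM

In an assay on MDA-MB-231 cells for binding affinity to C-X-C chemokine receptor type 4 (Homo sapiens), read by immunofluorescence and microscopy, with stated times of 10 min and 30 min (on this read-out higher numbers stand for an effect only at larger amounts of compound and lower numbers for an effect already at smaller amounts), compound 1 gives 10 nM and compound 2 gives 10 nM; the step of no change at the digits printed from compound 1 to compound 2 (within the scatter) lies within the scatter, so compound 2 stands level with compound 1. Compound 3 `Cc1ccc(S(=O)(=O)NCc2ccc(CNC(=O)c3ccccc3C)cc2)cc1` differs from compound 2 by 2-methylphenyl in place of 2,4,6-trichlorophenyl on a carbonyl carbon. Among the measured compounds shown here, the only measured step that bears on this change is no change at the digits printed from compound 1 to compound 2 (within the scatter), where swapping the aryl group on the carbonyl carbon left the value unchanged. Because no change at the digits printed from compound 1 to compound 2 (within the scatter) showed nothing beyond the scatter, the expected step is a 1.2-fold higher number from compound 2 to compound 3 (0.08 log units; within the scatter). Compound 3 is therefore estimated at 12 nM, with a range of 4 nM to 40 nM.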

Compound 3, effective concentration (reported as EC, without a stated level of effect): 100 nM
Compound 3: middle estimate off by 8.3-fold (0.92 log units), on the low side, outside the stated range (above it).
By their numbers in this assay, from the lowest: compounds 1 and 2 (each within the scatter of the next); then compound 3.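

In this assay the aryl group on the carbonyl carbon proves able to shift the value beyond the scatter (a 10-fold higher number from compound 2 to compound 3 (1.00 log units; beyond the scatter)), with 2-methylphenyl in place of 2,4,6-trichlorophenyl. Among the compounds shown here, the single change of methyl in place of chloro on an aromatic carbon gives the same size of step (a 10-fold higher number from compound 1 to compound 3 (1.00 log units; beyond the scatter)), so here the loss of chloro in the 2-chlorophenyl group matters, though the added chloro groups of compound 2 did not. Nothing measured here accounts for this difference.

Still open, on these data alone, is whether the value of compound 1 depends on chloro in particular or would also hold with fluoro, bromo or methoxy in its place. An unsubstituted phenyl group on the carbonyl carbon would show how much of the step belongs to the methyl group itself.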